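This account rests on a few compounds, and the source may have more. Where it says the series, first, only, none or still open, it means among the compounds named here.

Compound 1 `CCOc1ccc(/C=C(\C(=O)c2ccc(Cl)cc2)S(=O)(=O)Cc2ccc(C)cc2)cc1OC` is one of two compounds with a measured number in a functional assay on DU-145 cells (Homo sapiens) for inhibition, read by trypan blue exclusion, with a stated time of 96 h (a higher number here means a weaker inhibitor of growth, a lower number a stronger inhibitor of growth), and in it compound 1 gives 10000 nM. Compound 2 `Cc1ccc(CS(=O)(=O)/C(=C/c2ccc(Cl)cc2)C(=O)c2ccc(Cl)cc2)cc1` gives 25000 nM in this assay, so that there is a 2.5-fold higher number from compound 1 to compound 2 (0.40 log units; beyond the scatter). Going by the values given here, compound 1 therefore holds the lowest of the two numbers known so far. Compound 3 `CCOc1ccc(/C=C(/SCc2ccc(F)cc2)C(=O)c2ccc(Cl)cc2)cc1OC` differs from compound 1 at another place altogether: (4-fluorobenzyl)sulfanyl in place of (4-methylbenzyl)sulfonyl on a double-bonded chain carbon bound to a carbonyl carbon and a double-bonded chain carbon. Among the compounds with values here, no measured step alters the (4-methylbenzyl)sulfonyl group of compound 1, so the single step at hand, a 2.5-fold higher number from compound 1 to compound 2 (0.40 log units; beyond the scatter), says nothing about the direction this change should take; the outcome rests on an untested part of the shared core. Within the data shown here, the expectation for compound 3 in this assay is therefore a number close to that of compound 1, with no step expected beyond the scatter: no change at the digits printed from compound 1 to compound 3 (within the scatter). Compound 3 is estimated at 10000 nM, in a range expected from 2500 nM to 40000 nM.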

Compound 3, concentration for 50% growth inhibition: 1000 nM
Compound 3: middle estimate off by 10-fold (1.00 log units), on the high side; measured number below the stated range.
By their numbers in this assay, from the lowest: compound 3; then compound 1; then compound 2.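

In this assay, going by these compounds alone, the step of a 10-fold lower number from compound 1 to compound 3 (1.00 log units; beyond the scatter) gives the first reading at this place, on a double-bonded chain carbon bound to a carbonyl carbon and a double-bonded chain carbon, and it shows that the number responds to the group there. The change from (4-methylbenzyl)sulfonyl to (4-fluorobenzyl)sulfanyl alters both the sulfur group and the substituent on the benzyl ring, so this one step cannot be divided between the two. Nothing available explains the size or direction of the step.

From the compounds shown here alone, it remains open whether (4-methylbenzyl)sulfanyl or (4-fluorobenzyl)sulfonyl would give a number closer to that of compound 3 or of compound 1. Also open, going by these compounds, is how a group without a benzyl part, such as a simple amine or a carboxylic acid, would behave at this place.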